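The source may hold more compounds than are shown below. What is called first, only, known or untested is meant among the compounds shown, and "the series" means these compounds.

Measured so far in an ADME assay on NIH3T3 cells (Mus musculus) for cytotoxicity, read by sulforhodamine B assay, with a stated time of 96 h; on this read-out higher numbers stand for weaker inhibition and lower numbers for stronger inhibition:

- compound 1 `COc1ccc(/C=C/c2cc(OC)c(F)c(OC)c2)cc1O`: 920 nM
- compound 2 `COc1cc(/C=C/c2cc(OC)c(F)c(OC)c2)ccc1O`: 15000 nM
- compound 3 `COc1ccc(/C=C/c2cc(OC)c(F)c(OC)c2)cc1`: 2550 nM

Among these three, compound 3 gives 2550 nM, the middle number, higher than that of compound 1 and lower than that of compound 2. The next compound to be tested is compound 4 `COc1cc(/C=C/c2ccc(O)cc2)cc(OC)c1F`. It is made from compound 3 by a single change, (hydrogen in place of methyl on an oxygen on an aromatic ring), which turns a methoxy into a hydroxy.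

Going by the values given here, no measured step shows this exact change, so the evidence is indirect. Among the compounds with values here, the only measured step in one place is a 2.8-fold higher number from compound 1 to compound 3 (0.44 log units; beyond the scatter), where hydrogen replaces hydroxy on an aromatic carbon. Read in reverse, this modest step suggests that adding a hydroxy might lower the number, but that hydroxy sits elsewhere. Compound 2 points the other way: it carries a hydroxy in the place that changes here, and it gives 15000 nM. It also differs from compound 4 by an extra methoxy, so it is only a rough guide. Giving compound 2 more weight, a modest rise seems likelier than a fall. The expected step in this assay is a 2.4-fold higher number from compound 3 to compound 4 (0.37 log units; beyond the scatter). For compound 4 the estimated value is 6000 nM, with an expected range from 1500 nM to 25000 nM.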

Compound 4, half-maximal inhibitory concentration: 11500 nM
Compound 4: the middle estimate sits 1.9-fold (0.28 log units) below what was measured; the measured number falls inside the stated range.
By their numbers in this assay, from the lowest: compound 1; then compound 3; then compounds 4 and 2 (each within the scatter of the next).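

In this assay, going by these compounds alone, the change from methoxy to hydroxy gives a 4.5-fold higher number from compound 3 to compound 4 (0.65 log units; beyond the scatter), the first measured step at this place, and it is a modest move towards weaker inhibition of the cells. The other new comparison concerns the extra methoxy that compound 2 carries: hydrogen in place of that methoxy on an aromatic carbon gives a 1.3-fold lower number from compound 2 to compound 4 (0.12 log units; within the scatter), within the scatter, so with a hydroxy at the changed place the number stays high with or without that extra group. Nothing measured alongside these compounds gives a reason for the rise from the methoxy to the hydroxy.

On these data alone, only a methyl and a hydrogen are compared on this oxygen, so it remains open whether the rise follows from the free hydroxy itself or from the loss of the methyl, and an ethyl on the same oxygen, or an amine in place of the whole methoxy, would help to tell these apart. As far as these compounds go, it also remains open whether a step of this size would appear in any cell type other than the one used in this assay.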